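This account rests on a few compounds, and the source may have more. Where it says the series, first, only, none or still open, it means among the compounds named here.

Among the compounds with values here, compound 1 `CCCCCCCC/C=C\CCCCCCC(=O)c1nc2ncccc2o1` is the stronger of the two compounds measured so far in an assay on isolated protein for inhibition of Fatty-acid amide hydrolase 1 (Homo sapiens); a lower number here means a stronger inhibitor, a higher number a weaker inhibitor: compound 1 gives 2.3 nM, while compound 2 `O=C(CCCCSCc1ccccc1)c1ncc(-c2ccccn2)o1` gives 25 nM, a gap that lies beyond the usual scatter. Compound 1 therefore stands at the lowest number in the set. Compound 3 `CCCCCCCC/C=C\CCCCCCC(=O)c1nnn(C)n1` has not yet been measured in this assay. It differs from compound 1 in one place: a group of 6 heavy atoms (2 carbon, 4 nitrogen; one five-membered aromatic ring with 4 hetero atoms) in place of a group of 9 heavy atoms (6 carbon, 2 nitrogen, 1 oxygen; one five-membered aromatic ring with 2 hetero atoms, one six-membered aromatic ring with 1 hetero atom), on a carbonyl carbon. The long unsaturated chain and the carbonyl are kept, and only the ring system attached to that carbonyl carbon is exchanged. Within the data shown here, no measured pair in the set shows what such an exchange of the ring attached to the carbonyl does, so the expectation rests on the numbers alone. For compound 3 the step is expected to be a rise in the inhibition constant, clearly beyond the scatter, of roughly a 170-fold higher number from compound 1 to compound 3 (2.24 log units; beyond the scatter). Compound 3 is therefore estimated at 400 nM in this assay, with a range from 80 nM to 2000 nM.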

Compound 3, inhibition constant: 65 nM
The estimate for compound 3 lay 6.2-fold (0.79 log units) above the measured number, outside the stated range (below it).
By their numbers in this assay, from the lowest: compound 1; then compound 2; then compound 3.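

Within the data shown here, with the long unsaturated chain and the carbonyl held constant, the exchange of the ring system on this carbonyl carbon for 2-methyl-2H-tetrazol-5-yl gives the first direct reading of this position in this assay, a large step of a 28-fold higher number from compound 1 to compound 3 (1.45 log units; beyond the scatter) in the inhibition constant. The group on the carbonyl carbon therefore has a strong bearing on the measured inhibition, although the exchange does not remove it, since compound 3 still gives 65 nM with the smaller, single ring in place. Nothing available bears on why the number rises with this exchange.

This single step replaces the whole group at once, so the compounds shown leave open whether the rise goes with the loss of the six-membered aromatic ring, with the change in the five-membered aromatic ring, or with both together. They also leave open how the same chain and carbonyl would read with a different ring on that carbonyl carbon, such as a thiazole or a pyridine, which could help to separate these possibilities.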